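Replacing a fluorobenzyl with cyclohexyl: permeability expectation

The source may report more compounds than this note shows. Statements on the series, on what has been measured and on what is new or still open speak of the compounds shown alone.

Compound 1 `Fc1ccc(Cc2ccc3c(NCCCNCc4ccco4)ccnc3c2)cc1`: 23 10^-6 cm/s
Compound 2 `COc1ccc(F)cc1CNCCCNc1ccnc2cc(Cc3ccc(F)cc3)ccc12`: 23 10^-6 cm/s
Compound 3 `FC(F)(F)c1cccc(Cc2ccc3c(NCCCNCc4ccco4)ccnc3c2)c1`: 23 10^-6 cm/s

In an ADME assay for permeability, using PAMPA, with a stated time of 30 min, at pH 7.4 (on this read-out higher numbers stand for higher permeability and lower numbers for lower permeability), compound 1 gives 23 10^-6 cm/s, level with compound 2 and compound 3 at the digits shown. The two measured steps, no change at the digits printed from compound 1 to compound 2 (within the scatter) and no change at the digits printed from compound 1 to compound 3 (within the scatter), both stay within the scatter. Compound 4 `c1coc(CNCCCNc2ccnc3cc(C4CCCCC4)ccc23)c1` differs from compound 1 in one place: cyclohexyl in place of 4-fluorobenzyl on an aromatic carbon. Going by the values given here, no measured step touches this position, so there is no direct comparison for this change. Because the two changes elsewhere on the shared core gave no change at the digits printed from compound 1 to compound 2 (within the scatter) and no change at the digits printed from compound 1 to compound 3 (within the scatter), a step of about a 1.0-fold lower number from compound 1 to compound 4 (0.02 log units; within the scatter) is expected, with no shift beyond the scatter. Compound 4 is therefore estimated at 22 10^-6 cm/s, with a likely range from 12 10^-6 cm/s to 40 10^-6 cm/s.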

Compound 4, apparent permeability: 23 10^-6 cm/s
For compound 4 the middle estimate is 1.0-fold (0.02 log units) below the measured one; the measured number falls inside the stated range.
By their numbers in this assay, from the lowest: compounds 1, 2, 3 and 4 (each within the scatter of the next).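

In this assay, going by these compounds alone, cyclohexyl in place of 4-fluorobenzyl on an aromatic carbon gives no change at the digits printed from compound 1 to compound 4 (within the scatter) and is the first measured step at this position. A non-aromatic ring of carbon only, with 6 heavy atoms against 8 and no fluorine, is therefore accepted here without a shift beyond the scatter. Nothing available explains this result.

Still open, as far as these compounds go, is whether a group holding an amine or a carboxylic acid at this position would also leave the number within the scatter.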